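This account rests on a few compounds, and the source may have more. Where it says the series, first, only, none or still open, it means among the compounds named here.

All three measured compounds were tested in a functional assay, with a stated time of 20 min, tested at 20 uM; on this read-out lower numbers stand for a weaker effect and higher numbers for a stronger effect at the one concentration tested:

compound 1, `COc1cc(/C=C/C(=O)C2=C(/C=C/c3ccc(O)c(OC)c3)NC(=O)NC2c2ccccc2O)ccc1O`, gives 81%
compound 2, `COc1cc(/C=C/C(=O)C2=C(/C=C/c3ccc(O)c(OC)c3)NC(=O)NC2c2ccc(N(C)C)cc2)ccc1O`, gives 48%
compound 3, `COc1cc(/C=C/C(=O)C2=C(/C=C/c3ccc(O)c(OC)c3)NC(=S)NC2c2ccccc2O)ccc1O`, gives 72.3%

Compound 1 and compound 2 share a core and differ in one place, (4-(dimethylamino)phenyl in place of 2-hydroxyphenyl on a saturated ring carbon). This change gave a number 33 percentage points lower from compound 1 to compound 2 (beyond the scatter). Compound 3 has a core of its own; how that core differs from the core of compound 1 is not broken down here. In this assay compound 3 and compound 1 give numbers that lie within the scatter of each other, whereas compound 2 lies beyond the scatter below both of them.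

The unmeasured compound 4, `COc1cc(/C=C/C(=O)C2=C(/C=C/c3ccc(O)c(OC)c3)NC(=S)NC2c2ccc(N(C)C)cc2)ccc1O`, is derived from compound 3 by 4-(dimethylamino)phenyl in place of 2-hydroxyphenyl on a saturated ring carbon. Among the compounds with values here, this is the same change, at the same place, as the one that turned compound 1 into compound 2. Within the data shown here, with only one earlier instance of this change to rest on, the expectation is that it behaves the same way on the core of compound 3, so the expected step is a number 32.3 percentage points lower from compound 3 to compound 4 (beyond the scatter), set beside the step of a number 33 percentage points lower from compound 1 to compound 2 (beyond the scatter). On that basis compound 4 is estimated to give 40% in this assay, with a range from 25% to 55% that allows for the change falling somewhat differently on a core that is not the core of compound 1.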

Compound 4, a percentage reported as activity, at one concentration (the size of the read-out at that concentration, not a potency): 83%
For compound 4 the middle estimate is 43 percentage points below the measured one; measured number outside the range, above it.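

In this assay, putting 4-(dimethylamino)phenyl in place of 2-hydroxyphenyl on the saturated ring carbon gave a number 10.7 percentage points higher from compound 3 to compound 4 (beyond the scatter), so the change did not carry over from one core to the other, in either direction or size: the same change on two cores in this assay, a number 33 percentage points lower (beyond the scatter) from compound 1 to compound 2 and a number 10.7 percentage points higher (beyond the scatter) from compound 3 to compound 4, 43.7 percentage points apart, beyond the scatter of two such steps Within these four compounds, the effect of this exchange therefore depends on the core that carries it, and the step measured on the core of compound 1 gives no reliable guide to the step on the core of compound 3. This does not show why the two steps part, which feature of the cores is responsible, or how the change would fall on any further core, and with one pair on each core it establishes no rule for the series as a whole.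

The compounds shown leave open how other groups on the same saturated ring carbon, such as an unsubstituted phenyl, a 4-methoxyphenyl or a 4-(diethylamino)phenyl, would behave on each of the two cores. They also leave open whether a 3-hydroxyphenyl or a 4-hydroxyphenyl would follow the step seen on the core of compound 1 or the one seen on the core of compound 3.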